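Removing the carbamate from a melatonin receptor ligand

The source may hold more compounds than are shown below. What is called first, only, known or untested is meant among the compounds shown, and "the series" means these compounds.

Measured compounds:
- compound 1, `CC(=O)NCCN(C)c1cccc(OCCCCCCNC(=O)Oc2cccc(-c3ccccc3)c2)c1`: 21.4 nM
- compound 2, `CC(=O)NCCN(C)c1cccc(OCCCCOc2cccc(OC(=O)NC3CCCCC3)c2)c1`: 34.7 nM
- compound 3, `CC(=O)NCCN(C)c1cccc(OCCCCNC(=O)Oc2cccc(-c3ccccc3)c2)c1`: 12.9 nM

All three share a core that carries an acetamide chain and a long linker ending in a carbamate. In an assay on cells for displacement of a labelled ligand from melatonin receptor type 1A (Homo sapiens), using the Cheng-Prusoff equation, with a stated time of 90 min (on this read-out higher numbers stand for weaker inhibition and lower numbers for stronger inhibition), compound 2 shows the highest of the three numbers. Compound 1 lies closest to it, within the usual scatter, so no order between compound 1 and compound 2 can be claimed. Compound 3, with its shorter linker, gives a lower number than compound 2 by a margin beyond the scatter.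

Compound 4, `CC(=O)NCCN(C)c1cccc(OCCCCOc2cccc(O)c2)c1`, has not been measured. Its difference from compound 2 is hydrogen in place of cyclohexylcarbamoyl on an oxygen on an aromatic ring. The whole cyclohexylcarbamoyl group is gone, and a plain hydroxy remains on the ring.

Going by the values given here, no directly comparable pair among the measured compounds isolates this change, so the expectation rests on the fact that every measured compound keeps a carbamate. Losing it is expected to weaken binding, that is, to raise the number in this assay by a step larger than the scatter. Compound 4 is therefore estimated at 120 nM, within a range from 35 nM to 450 nM. The expected step is a 3.5-fold higher number from compound 2 to compound 4 (0.54 log units; beyond the scatter).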

Compound 4, inhibition constant: 186 nM
Compound 4: the middle estimate sits 1.6-fold (0.19 log units) below what was measured; low and high end bracket the measured number.
By their numbers in this assay, from the lowest: compounds 3, 1 and 2 (each within the scatter of the next, the first and the last beyond it); then compound 4.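

Until now every compound carried a carbamate, so nothing showed what that group contributes. In this assay, replacing cyclohexylcarbamoyl with hydrogen on an oxygen on an aromatic ring gives a 5.4-fold higher number from compound 2 to compound 4 (0.73 log units; beyond the scatter), a modest change but one that exceeds the usual scatter, so the group does count at this position, while its complete removal still leaves compound 4 with a measurable 186 nM rather than abolishing binding. Nothing available explains why the number rises, so this step records the size of the change and not its cause.

This single step removes the cyclohexyl ring, the carbonyl and the amide hydrogen together, so it cannot show which of these parts matters, and a smaller methylcarbamoyl group or a simple methyl on the same oxygen would help to separate them. Also open, going by these compounds, is whether a step of this size would appear in the other carbamates, compound 1 and compound 3, whose carbamates are built differently and sit on different linkers.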